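A few compounds are considered here, and "the series" means these few. Any claim that something is new, unique, unknown or untested is made for them only; others in the source may bear on it.

The measured compounds:

compound 1, `CC(Oc1ccc(Oc2ccc(F)cc2)cc1)C(=O)Cn1nnc(-c2ccccc2)n1`, 24 nM
compound 2, `CC(Oc1ccc(Oc2ccc(Cl)cc2)cc1)C(=O)Cn1nnc(-c2ccccc2)n1`, 51 nM
compound 3, `COC(=O)c1ccc(-c2nnn(CC(=O)C(C)Oc3ccc(Oc4ccc(F)cc4)cc3)n2)cc1`, 36 nM

All three numbers come from an assay on microsomes from brain for inhibition of Fatty-acid amide hydrolase 1 (Rattus norvegicus), read by fluorescence and HPLC, with a stated time of 60 min; on this read-out higher numbers stand for weaker inhibition and lower numbers for stronger inhibition. Compound 1 and compound 2 share one core and differ by chloro in place of fluoro on an aromatic carbon; this change gave a 2.1-fold higher number from compound 1 to compound 2 (0.33 log units; beyond the scatter). Compound 3 differs from compound 1 in its core by methoxycarbonyl in place of hydrogen on an aromatic carbon, a change that gave a 1.5-fold higher number from compound 1 to compound 3 (0.18 log units; within the scatter). Compound 4, `COC(=O)c1ccc(-c2nnn(CC(=O)C(C)Oc3ccc(Oc4ccc(Cl)cc4)cc3)n2)cc1`, has not yet been measured in this assay. It carries the core of compound 3 and differs from it by chloro in place of fluoro on an aromatic carbon. The place of the change is the same as between compound 1 and compound 2, so the change is the same one, seen a second time on the other core. This rests on compound 1 and compound 2, whose step is a 2.1-fold higher number from compound 1 to compound 2 (0.33 log units; beyond the scatter), and on compound 3 at 36 nM as the starting point. The expected step from compound 3 to compound 4 is accordingly a 2.1-fold higher number from compound 3 to compound 4 (0.32 log units; beyond the scatter). Compound 4 is therefore estimated at 75 nM, between 35 nM and 160 nM, in this assay.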

Compound 4, half-maximal inhibitory concentration: 47 nM
The estimate for compound 4 lay 1.6-fold (0.20 log units) above the measured number; low and high end bracket the measured number.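

In this assay, chloro in place of fluoro gave a 1.3-fold higher number from compound 3 to compound 4 (0.12 log units; within the scatter), and this step does not differ measurably from the one seen on the other core: the same change on two cores in this assay, a 2.1-fold higher number (0.33 log units; beyond the scatter) from compound 1 to compound 2 and a 1.3-fold higher number (0.12 log units; within the scatter) from compound 3 to compound 4, 1.6-fold (0.21 log units) apart, within the scatter of two such steps Methoxycarbonyl in place of hydrogen gave a 1.1-fold lower number from compound 2 to compound 4 (0.04 log units; within the scatter), and this step likewise agrees with its earlier counterpart: the same change on two cores in this assay, a 1.5-fold higher number (0.18 log units; within the scatter) from compound 1 to compound 3 and a 1.1-fold lower number (0.04 log units; within the scatter) from compound 2 to compound 4, 1.6-fold (0.21 log units) apart, within the scatter of two such steps The two changes therefore carried from one core to the other without a detectable departure, but this does not show that the chloro step has the same size on both cores, since it lies beyond the scatter on one core and within it on the other, and a single pair of cores cannot establish a general rule for the series.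

The compounds shown leave open whether the agreement would hold for bromo in place of chloro, or for a carboxylic acid or a nitrile in place of methoxycarbonyl. They also leave open whether it would survive a change elsewhere in the shared core, such as a longer chain in place of the methyl group.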